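Swapping a ketone for an amide on a bridged core

The source may report more compounds than this note shows. Statements on the series, on what has been measured and on what is new or still open speak of the compounds shown alone.

Compound 3 `O=C(C1CC1)[C@H]1C[C@@H]2CNC[C@@H](C2)C1` carries a cyclopropyl ketone on a bridged bicyclic core that contains a secondary amine. In an assay on SHEP1 cells for agonist activity at Neuronal acetylcholine receptor; alpha4/beta2 (Homo sapiens), read by FLIPR and calcium flux (on this read-out lower numbers stand for an effect already at smaller amounts and higher numbers for an effect only at larger amounts of compound), compound 3 gives 7100 nM, the highest of the two numbers available. Compound 1 `O=C(C1CC1)[C@H]1C[C@H]2CNC[C@H]2C1` has the same cyclopropyl ketone on a different, fused core and gives 18 nM, a number far lower than that of compound 3 and beyond the usual scatter. Compound 2 `CNC(=O)[C@H]1C[C@H]2CNC[C@H]2C1` puts a methylamide on the core of compound 1, but for compound 2 the result in this assay is recorded as "not determined" (no result reported), so it offers no number to compare.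

Compound 4 `CC(C)NC(=O)[C@H]1C[C@@H]2CNC[C@@H](C2)C1` keeps the core of compound 3 and differs in one place: isopropylamino in place of cyclopropyl on a carbonyl carbon. For the measured compounds named here, no pair among the measured compounds shows what replacing a ketone by an amide does on either core, so nothing here tells the direction of such a change. Starting from the already high number of compound 3 in this assay, compound 4 is expected to stay near that level, and the step of a 1.7-fold higher number from compound 3 to compound 4 (0.23 log units; within the scatter) is estimated to be small, with a drift toward a higher number. The expected result for compound 4 is therefore 12000 nM, within a range from 3000 nM to 50000 nM.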

Compound 4, half-maximal effective concentration: 1900 nM
Compound 4: middle estimate off by 6.3-fold (0.80 log units), on the high side, and the stated range ends above it.
By their numbers in this assay, from the lowest: compound 1; then compound 4; then compound 3.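

For the compounds shown here, on the core of compound 3, this pair gives the first direct reading of the change at this position. In this assay, isopropylamino in place of cyclopropyl on a carbonyl carbon, which turns the ketone into an amide, gives a 3.7-fold lower number from compound 3 to compound 4 (0.57 log units; beyond the scatter), a modest step toward a lower number. The entering group has no ring and brings a nitrogen with one hydrogen-bond donor, yet the number falls rather than rises, though nothing shown here explains this drop.

The change alters several things at once, removing the ring and adding the nitrogen, so this one pair cannot separate their contributions; an isopropyl ketone or a cyclopropylamino amide on the same core would help tell them apart. As far as these compounds go, it also remains open whether an amide has a similar effect on the core of compound 1, since the methylamide compound 2 has no number to set beside the ketone compound 1.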